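From Fluorophenyl to Dihydroxyphenyl on the Shared Core

This account rests on a few compounds, and the source may have more. Where it says the series, first, only, none or still open, it means among the compounds named here.

Among the compounds with values here, compound 1 `OC[C@H]1O[C@@H](n2cnc3c(NCc4cccc(F)c4)ncnc32)[C@H](O)[C@@H]1O` is the only member of this set with a number in a functional assay on K562 cells (Homo sapiens) for antiproliferative activity, with a stated time of 72 h; on this read-out higher numbers stand for weaker inhibition and lower numbers for stronger inhibition: compound 1 gives 7600 nM. Compound 2 `Cc1ccc(CNc2ncnc3c2ncn3[C@@H]2O[C@H](CO)[C@@H](O)[C@H]2O)cc1` reaches only a limit in this assay, > 166000 nM. Compound 3 `COc1cc(CNc2ncnc3c2ncn3[C@@H]2O[C@H](CO)[C@@H](O)[C@H]2O)cc(OC)c1` likewise reaches only a limit, > 166000 nM. The steps read an at least 21-fold higher number from compound 1 to compound 2 (1.33 log units; beyond the scatter) and an at least 21-fold higher number from compound 1 to compound 3 (1.33 log units; beyond the scatter), while the pair of compound 2 and compound 3 gives a step that the two limits leave unreadable from compound 2 to compound 3. Compound 4 `OC[C@H]1O[C@@H](n2cnc3c(NCc4cccc(O)c4O)ncnc32)[C@H](O)[C@@H]1O` differs from compound 1 by 2,3-dihydroxyphenyl in place of 3-fluorophenyl on a saturated chain carbon bound to a nitrogen on an aromatic ring. Both measured swaps on a saturated chain carbon bound to a nitrogen on an aromatic ring weakened inhibition sharply, as the limit of > 166000 nM in this assay, at which 2 of the 3 values shown sit, shows. A comparable weakening is therefore expected, an 11-fold higher number from compound 1 to compound 4 (1.02 log units; beyond the scatter), with a fair chance that only a limit is returned. Compound 4 is estimated at 80000 nM, within 12000 nM to 400000 nM.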

Compound 4, half-maximal inhibitory concentration: 25800 nM
The estimate for compound 4 lay 3.1-fold (0.49 log units) above the measured number; the range from low to high includes it.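

In this assay, a change at this place on a saturated chain carbon bound to a nitrogen on an aromatic ring need not end at a limit: 2,3-dihydroxyphenyl in place of 3-fluorophenyl gives a 3.4-fold higher number from compound 1 to compound 4 (0.53 log units; beyond the scatter). The same group, set against the earlier replacements, gives an at least 6.4-fold lower number from compound 3 to compound 4 (0.80 log units; beyond the scatter) and an at least 6.4-fold lower number from compound 2 to compound 4 (0.80 log units; beyond the scatter). Replacing 3-fluorophenyl thus weakened inhibition in all three compounds, but by a measurable amount in compound 4.

On these data alone, it remains open whether a phenyl group with a single hydroxyl would keep a measurable number. As far as these compounds go, how an aminophenyl or carboxyphenyl group would read at this place is also open.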